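Aryl hydrazones: from pyridin-2-yl to bromo-hydroxyphenyl

The source may hold more compounds than are shown below. What is called first, only, known or untested is meant among the compounds shown, and "the series" means these compounds.

The shared core is carried by compound 1 `Cc1c(C(=O)N/N=C\c2cccc(F)c2)oc2cccc(O)c12`, compound 2 `Cc1c(C(=O)N/N=C\c2cc(O)ccc2O)oc2cccc(O)c12`, compound 3 `Cc1c(C(=O)N/N=C\c2ccccn2)oc2cccc(O)c12` and the still unmeasured compound 4 `Cc1c(C(=O)N/N=C\c2cccc(Br)c2O)oc2cccc(O)c12`. In a functional assay on PC-3 cells (Homo sapiens) for inhibition (a lower number here means a stronger inhibitor, a higher number a weaker inhibitor), compound 1 gives >= 40000 nM, which is a limit of the assay and not a number. In this assay compound 2 gives 95500 nM. In this assay compound 3 gives >= 40000 nM, again a limit of the assay. Compound 3 thus stands at the limit, which is shared by one other value, as the limit of >= 40000 nM in this assay, at which 2 of the 3 values shown sit, records. The change to compound 4 is 3-bromo-2-hydroxyphenyl in place of pyridin-2-yl on a carbon with a double bond to nitrogen. The measured steps that bear on this change are a step that the two limits leave unreadable from compound 1 to compound 3, a step that the limit leaves unreadable from compound 2 to compound 3 and a step that the limit leaves unreadable from compound 1 to compound 2. None of them has a readable size. No step beyond the scatter can therefore be expected in this assay in either direction. Compound 4 is expected at 60000 nM, within 15000 nM to 200000 nM, and the expected step that the limit leaves unreadable from compound 3 to compound 4 is estimated to stay inside the scatter.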

Compound 4, half-maximal inhibitory concentration: 16600 nM
Compound 4: the middle estimate sits 3.6-fold (0.56 log units) above what was measured; measured number inside the range.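

In this assay, within the data shown here, 3-bromo-2-hydroxyphenyl on the carbon with a double bond to nitrogen gives the first step of readable size, a 5.8-fold lower number from compound 2 to compound 4 (0.76 log units; beyond the scatter). Compound 1 and compound 3 each sit at a limit of the assay and not at a number: the limit of >= 40000 nM in this assay, at which 2 of the 4 values shown sit. Against those two compounds the change therefore has only a bounded size, seen as an at least 2.4-fold lower number from compound 3 to compound 4 (0.38 log units; beyond the scatter) and as an at least 2.4-fold lower number from compound 1 to compound 4 (0.38 log units; beyond the scatter), yet compound 4 now has the lowest number of the four, so the aryl group at this place does move the read-out beyond the scatter.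

The compounds shown do not separate the share of the bromo group from that of the hydroxy group in 3-bromo-2-hydroxyphenyl. Going by these compounds, how an aryl group carrying an amine or a carboxylic acid would read at this place in this assay also stays open.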